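A Repeated Aryl Exchange and an Expected Growth Inhibition

The source may hold more compounds than are shown below. What is called first, only, known or untested is meant among the compounds shown, and "the series" means these compounds.

Compound 1 `COc1cc(/C=C/C(=O)/C=C/c2cc(OC)c(OC)c(OC)c2)ccc1OCc1cn(CCOc2cc(=O)oc3ccccc23)nn1`, compound 2 `COc1cc(/C=C/C(=O)/C=C/c2ccccc2)ccc1OCc1cn(CCOc2cc(=O)oc3ccccc23)nn1` and compound 3 `COc1cc(/C=C/C(=O)/C=C/c2ccccc2)ccc1OCc1cn(CCCOc2cc(=O)oc3ccccc23)nn1` were tested in a functional assay on HCT-116 cells (Homo sapiens) for inhibition, read by sulforhodamine B assay, with a stated time of 48 h, tested at 50 uM; on this read-out higher numbers stand for more inhibition of growth at the one concentration tested and lower numbers for less inhibition of growth. Compound 1 gives 89%, compound 2 gives 56% and compound 3 gives 45%, the lowest of the three. Compound 1 differs from compound 2 by a single change, (3,4,5-trimethoxyphenyl in place of phenyl on a double-bonded chain carbon bound to a double-bonded chain carbon), and that change made a step of a number 33 percentage points higher from compound 2 to compound 1 (beyond the scatter). Compound 4 `COc1cc(/C=C/C(=O)/C=C/c2cc(OC)c(OC)c(OC)c2)ccc1OCc1cn(CCCOc2cc(=O)oc3ccccc23)nn1` has not yet been measured in this assay. It stands to compound 3 as compound 1 stands to compound 2: 3,4,5-trimethoxyphenyl in place of phenyl on a double-bonded chain carbon bound to a double-bonded chain carbon, the same change at the same place. Among the measured compounds shown here, how the core of compound 2 and the core of compound 3 differ is not broken down here; their values in this assay show only that compound 3 sits lower than compound 2. A step of about the same size is expected for compound 4, a number 33 percentage points higher from compound 3 to compound 4 (beyond the scatter), because the same change carried compound 2 to compound 1 by a number 33 percentage points higher from compound 2 to compound 1 (beyond the scatter). Compound 4 is therefore estimated at 78%, with a likely range from 62% to 92%.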

Compound 4, percent growth inhibition at one concentration: 76%
Beside the measured number, compound 4's estimate is 2 percentage points above it; the range from low to high includes it.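

In this assay, 3,4,5-trimethoxyphenyl in place of phenyl on a double-bonded chain carbon bound to a double-bonded chain carbon gave a number 31 percentage points higher from compound 3 to compound 4 (beyond the scatter). Set beside the earlier step, the change carried over from one core to the other with its size preserved: the same change on two cores in this assay, a number 33 percentage points higher (beyond the scatter) from compound 2 to compound 1 and a number 31 percentage points higher (beyond the scatter) from compound 3 to compound 4, 2 percentage points apart, within the scatter of two such steps. Among the compounds shown here, this shows that the gain did not depend on which of these two cores carried it, but it rests on only two pairs at a single concentration and does not explain why the exchange raises growth inhibition or show that it would hold on any other core.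

The compounds shown leave open whether a single methoxy group, a chlorine atom or an amine on that aromatic ring would give a step of similar size. They also leave open whether the same exchange would keep its size on a core with a longer chain than that of compound 3.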